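Series notes: methoxy to propoxy on the anilide ring

This account rests on a few compounds, and the source may have more. Where it says the series, first, only, none or still open, it means among the compounds named here.

Two compounds share a common core and an amide-capped thioether chain. Compound 1 `Cn1c(Cc2nn(C)c(=O)c3ccccc23)nnc1SCCCCCCCCCCC(=O)Nc1ccc(Cl)cc1Cl` carries a dichlorophenyl anilide and is recorded in an assay on isolated protein for binding affinity to interleukin-15 (Homo sapiens), read by surface plasmon resonance (a lower number here means tighter binding, a higher number weaker binding), as "not determined" (no result reported); no number exists for it. Compound 2 `COc1ccc(NC(=O)CCCCCCCSc2nnc(Cc3nn(C)c(=O)c4ccccc34)n2C)cc1` carries a methoxyphenyl anilide and in this assay gives 26000 nM. Among the compounds with values here, compound 2 therefore stands alone as the only numbered entry in this assay, a weak binder, and no step between measured compounds is available to calibrate substituent effects.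

Compound 3 `CCCOc1ccc(NC(=O)CCCCCCCSc2nnc(Cc3nn(C)c(=O)c4ccccc34)n2C)cc1` is the next member to be measured. Relative to compound 2 the change is ethyl in place of hydrogen on a saturated chain carbon bound to an oxygen on an aromatic ring. Within the data shown here, no measured pair informs a change of this kind, so there is no basis for expecting a step beyond the usual scatter; the chain is lengthened modestly and the remainder of the molecule is unchanged.

The working expectation is that the step from compound 2 to compound 3 is a 1.3-fold lower number from compound 2 to compound 3 (0.11 log units; within the scatter), that is, no shift beyond scatter. Compound 3 is accordingly estimated in this assay at 20000 nM, within a range from 7000 nM to 60000 nM. The measured value for compound 3 follows.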

Compound 3, dissociation constant: 19000 nM
Compound 3: the middle estimate sits 1.1-fold (0.02 log units) above what was measured, and the stated range covers the measured number.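

Ethyl in place of hydrogen on a saturated chain carbon bound to an oxygen on an aromatic ring gives a 1.4-fold lower number from compound 2 to compound 3 (0.14 log units; within the scatter) in this assay, the first step in the series that can be read at all. Within the data shown here, it shows that, for this pair, going from 4-methoxyphenyl to 4-propoxyphenyl adds 2 carbon atoms at this position without moving the number beyond the scatter, so the position accepts this change with the rest of the molecule held constant, and the single pair supports no trend with chain length. No measurement is available that bears on the reason for this result.

Still open, as far as these compounds go, is whether a longer chain than propoxy, or an amine or a carboxylic acid carried at the end of the chain on this oxygen, would produce a step beyond the scatter. Also open, from the compounds shown here alone, is how other groups on the anilide ring compare with these two, since compound 1, recorded as "not determined" (no result reported), gives no number to set beside compound 2 or compound 3.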